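Chloro substitution on the phenoxy ring of a thymine series

This account rests on a few compounds, and the source may have more. Where it says the series, first, only, none or still open, it means among the compounds named here.

Working notes on a small set of thymine-bearing piperidines. The reference point is compound 1 `Cc1cn(C2CCN(Cc3cccc(Oc4ccccc4)n3)CC2)c(=O)[nH]c1=O`, carrying a plain phenoxy group. In an ADME assay on MRC5 cells (Homo sapiens) for cytotoxicity, read by fluorescence and resazurin assay, with a stated time of 3 days (a lower number here means a stronger inhibitor, a higher number a weaker inhibitor), compound 1 reaches only the limit of the assay, > 64000 nM, so no single number is known for it; this is the case described by the limit of > 64000 nM in this assay, at which 1 of the 3 values shown sits. A close relative, compound 2 `Cc1cn(C2CCN(Cc3cccc(Oc4ccccc4)c3)CC2)c(=O)[nH]c1=O`, has no result in this assay: "not determined" (no result reported). Among the measured compounds shown here, the one numerical value in the set belongs to compound 3 `COc1cccc(Oc2cccc(CN3CCC(n4cc(C)c(=O)[nH]c4=O)CC3)c2)c1`, which in this assay gives 25300 nM. For the measured compounds named here, because compound 1 stands only at a limit, no step between measured compounds can be computed here, and where compound 1 sits relative to compound 3 is not known beyond its being at or past the limit.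

The next compound, compound 4 `Cc1cn(C2CCN(Cc3cccc(Oc4cccc(Cl)c4)n3)CC2)c(=O)[nH]c1=O`, differs from compound 1 in one place: chloro in place of hydrogen on an aromatic carbon. With only a limit on one side, the step between these two compounds cannot be anchored firmly. The estimated step is an at least 1.2-fold lower number from compound 1 to compound 4 (0.10 log units; that floor lies within the scatter), which is expected to stay within the scatter of this assay. For compound 4 the estimated value in this assay is 50000 nM, with a range from 15000 nM to 150000 nM, and it is expected that the assay again reports a limit rather than a number.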

Compound 4, half-maximal inhibitory concentration: > 64000 nM
Compound 4 was reported as a limit; the forecaster's own chance of this, stated with the estimate: 55%; middle value at least 1.2-fold (0.10 log units) away from the limit.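

In this assay compound 4 gives > 64000 nM as a limit and not a number. Among the compounds shown here, compound 1 also stands at a limit, so no step from compound 1 to compound 4 can be read: the limit of > 64000 nM in this assay, at which 2 of the 4 values shown sit. The compounds shown leave open how far, if at all, chloro in place of hydrogen shifts the value.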